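The source may hold more compounds than are shown below. What is called first, only, known or untested is meant among the compounds shown, and "the series" means these compounds.

In a functional assay on SU-DHL-6 cells (Homo sapiens) for antiproliferative activity, read by MTT assay (a higher number here means a weaker inhibitor, a lower number a stronger inhibitor), compound 1 (`COc1ncc(-c2ccc3ncnc(N[C@H]4CCCN(C(=O)C(F)(F)F)C4)c3c2)cc1C#N`) gives 210 nM, compound 2 (`COc1ncc(-c2ccc3ncnc(N[C@H]4CCCN(C(=O)c5cccnc5)C4)c3c2)cc1C#N`) gives 120 nM and compound 3 (`COc1ncc(-c2ccc3ncnc(N[C@H]4CCCN(C(=O)CN(C)C)C4)c3c2)cc1C#N`) gives 160 nM. Compound 1 thus stands within the scatter of both others: a 1.8-fold lower number from compound 1 to compound 2 (0.24 log units; within the scatter) and a 1.3-fold lower number from compound 1 to compound 3 (0.12 log units; within the scatter), while a 1.3-fold higher number from compound 2 to compound 3 (0.12 log units; within the scatter). Compound 4 (`COc1ncc(-c2ccc3ncnc(N[C@H]4CCCN(C(=O)C(F)(F)F)C4)c3c2)cc1[N+](=O)[O-]`) keeps the trifluoromethyl on the carbonyl carbon and differs from compound 1 on an aromatic carbon, with nitro in place of cyano on an aromatic carbon. For the measured compounds named here, all three measured steps replace the group on the carbonyl carbon, so none tests this change directly, and no measured compound carries nitro. Only a small move towards a higher number is therefore expected, with a 1.4-fold higher number from compound 1 to compound 4 (0.15 log units; within the scatter) as the estimated step. For compound 4 the estimated value is 300 nM, within a range of 90 nM to 1000 nM.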

Compound 4, half-maximal inhibitory concentration: 127000 nM
For compound 4 the middle estimate is 420-fold (2.63 log units) below the measured one; the measured number lies above the stated range.
By their numbers in this assay, from the lowest: compounds 2, 3 and 1 (each within the scatter of the next); then compound 4.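

In this assay the aromatic carbon ortho to a methoxy group proves highly sensitive: nitro in place of cyano gives a 600-fold higher number from compound 1 to compound 4 (2.78 log units; beyond the scatter), while the three groups on the carbonyl carbon in compounds 1, 2 and 3 stay within the scatter of each other. Cyano and nitro are therefore not interchangeable at this position. Nothing available here bears on why the step is so large.

On these data alone, it remains open how an amine, a carboxylic acid or a chlorine atom would fare at this position. As far as these compounds go, it is also open whether nitro brings the same step with pyridin-3-yl or (dimethylamino)methyl on the carbonyl carbon.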